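Swapping a ring amine for dimethylamino on the shared core

This account rests on a few compounds, and the source may have more. Where it says the series, first, only, none or still open, it means among the compounds named here.

Measured in an ADME assay on L6 cells (Rattus norvegicus) for cytotoxicity; a higher number here means a weaker inhibitor, a lower number a stronger inhibitor:
Compound 1 `CN1CCN(CCCN2CCC3(N4CCCCC4)CC(c4ccccc4)C2C(c2ccccc2)C3)CC1`: 62500 nM
Compound 2 `CN1CCN(CCCN2CCC3(N4CCCC4)CC(c4ccccc4)C2C(c2ccccc2)C3)CC1`: 27500 nM
Compound 3 `CN1CCN(CCN2CCC3(N4CCCC4)CC(c4ccccc4)C2C(c2ccccc2)C3)CC1`: 50300 nM

Compound 2 gives the lowest number of the three. Its gap to compound 3 lies within the scatter, so the two cannot be ordered; the step of a 2.3-fold lower number from compound 1 to compound 2 (0.36 log units; beyond the scatter) is modest but beyond the scatter, so compound 1 sits clearly higher.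

Compound 4 `CN1CCN(CCCN2CCC3(N(C)C)CC(c4ccccc4)C2C(c2ccccc2)C3)CC1` has not yet been measured. It differs from compound 2 in one place: dimethylamino in place of pyrrolidin-1-yl on a saturated ring carbon.

Of the measured steps, only the change at the same saturated ring carbon bears on this: a 2.3-fold lower number from compound 1 to compound 2 (0.36 log units; beyond the scatter), where one ring amine replaced another. The step of a 1.8-fold higher number from compound 2 to compound 3 (0.26 log units; within the scatter) concerns a different part of the molecule and was within the scatter. With a single relevant step, and that one modest, compound 4 is expected to stay near compound 2, with at most a modest move in either direction in this assay; the expected step is a 1.3-fold lower number from compound 2 to compound 4 (0.10 log units; within the scatter).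

Compound 4 is therefore estimated at 22000 nM, within a range of 8000 nM to 60000 nM.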

Compound 4, half-maximal inhibitory concentration: 54500 nM
Compound 4: middle estimate off by 2.5-fold (0.39 log units), on the low side; measured number inside the range.
By their numbers in this assay, from the lowest: compounds 2, 3, 4 and 1 (each within the scatter of the next, the first and the last beyond it).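

In this assay, dimethylamino, which has no ring, gives a 2.0-fold higher number from compound 2 to compound 4 (0.30 log units; within the scatter) when it replaces pyrrolidin-1-yl and a 1.1-fold lower number from compound 1 to compound 4 (0.06 log units; within the scatter) when it replaces piperidin-1-yl. The two ring amines were separated by a 2.3-fold lower number from compound 1 to compound 2 (0.36 log units; beyond the scatter), yet compound 4 cannot be told apart from either of them, so at this saturated ring carbon the open-chain group has no clear place in the order. No measurement shown here explains these numbers.

Going by these compounds, it remains open whether a morpholin-4-yl ring or a diethylamino group on the same ring carbon would give a number clearly apart from these three. On these data alone, it is also open how dimethylamino would read out on the shorter chain of compound 3.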